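Removing a Methyl From a Weak Antiproliferative Compound

The source may report more compounds than this note shows. Statements on the series, on what has been measured and on what is new or still open speak of the compounds shown alone.

Compound 1 `COc1cc(OC)c2c(=O)n(-c3ccccc3)ccc2c1`: 5350 nM
Compound 2 `COc1cc(OC)c2c(=O)n(-c3cccc(C(=O)N4CCCCC4)c3)ccc2c1`: 15300 nM

Going by the values given here, in a functional assay on A-431 cells (Homo sapiens) for antiproliferative activity, read by MTT assay, with a stated time of 72 h (a higher number here means a weaker inhibitor, a lower number a stronger inhibitor), compound 2 gives 15300 nM, the higher of the two numbers so far; the single measured step, a 2.9-fold higher number from compound 1 to compound 2 (0.46 log units; beyond the scatter), separates it from compound 1. Compound 3 `COc1cc(O)c2c(=O)n(-c3cccc(C(=O)N4CCCCC4)c3)ccc2c1` differs from compound 2 by hydrogen in place of methyl on an oxygen on an aromatic ring. That measured step altered a different part of the molecule, so it says little about removing a methyl from an oxygen. Among the compounds with values here, with no comparable step available, no change beyond the scatter is expected. Compound 3 is therefore estimated at 15000 nM, within 5000 nM to 45000 nM. This estimate amounts to a 1.0-fold lower number from compound 2 to compound 3 (0.01 log units; within the scatter).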

Compound 3, half-maximal inhibitory concentration: 2250 nM
Estimate against measurement, compound 3: 6.7-fold (0.82 log units) above; measured number outside the range, below it.
By their numbers in this assay, from the lowest: compound 3; then compound 1; then compound 2.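

In this assay the change from methoxy to hydroxy gives a 6.8-fold lower number from compound 2 to compound 3 (0.83 log units; beyond the scatter) and so makes compound 3 the stronger inhibitor of this pair. This shows that a single methyl on this oxygen can matter, which the earlier step on a different part of the molecule could not show. Nothing measured here explains the shift.

Still open, on these data alone, is whether a longer chain on this oxygen, such as ethyl, would give a different number. As far as these compounds go, whether the other methoxy responds in the same way is also open.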